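The source may report more compounds than this note shows. Statements on the series, on what has been measured and on what is new or still open speak of the compounds shown alone.

Measured in a toxicity assay on GES1 cells (Homo sapiens) for inhibition, read by MTT assay, with a stated time of 72 h; on this read-out lower numbers stand for stronger inhibition and higher numbers for weaker inhibition:
- compound 1 `Cc1cc(N2CC[C@@H](C)[C@@H](N(C)c3ncnc4[nH]ccc34)C2)n2ncnc2n1`: 57900 nM
- compound 2 `Cc1cc(N2CC[C@@H](C)[C@@H](N(C)c3ncnc4[nH]ccc34)C2)n2nc(SCc3nc4ccccc4[nH]3)nc2n1`: 40200 nM

Among the measured compounds shown here, compound 2 stands level with the only other measured compound, and the single measured step is a 1.4-fold lower number from compound 1 to compound 2 (0.16 log units; within the scatter). Not yet measured is compound 3 `Cc1cc(N2CC[C@@H](C)[C@@H](N(C)c3ncnc4[nH]ccc34)C2)n2nc(SCc3csc4ccc(Cl)cc34)nc2n1`, which differs from compound 2 as follows: 5-chloro-1-benzothiophen-3-yl in place of 1H-benzimidazol-2-yl on a saturated chain carbon bound to a sulfur. That one step bears on this change only indirectly: it installed the ((1H-benzimidazol-2-yl)methyl)sulfanyl group, and the size of the step stayed within the scatter. For the measured compounds named here, no measured compound carries 5-chloro-1-benzothiophen-3-yl, so the range is kept wide. The expectation therefore starts from compound 2 at 40200 nM, with no shift beyond the scatter in this assay. The expected step is a 1.3-fold lower number from compound 2 to compound 3 (0.13 log units; within the scatter). For compound 3 the estimated value is 30000 nM, with an expected range of 10000 nM to 80000 nM.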

Compound 3, half-maximal inhibitory concentration: > 100000 nM
Compound 3: a limit, no number; the forecaster's own chance of this, stated with the estimate: 15%; middle value at least 3.3-fold (0.52 log units) away from the limit.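

In this assay compound 3 gives > 100000 nM, a limit of the assay and not a number. With 5-chloro-1-benzothiophen-3-yl in place of 1H-benzimidazol-2-yl on a saturated chain carbon bound to a sulfur, the read-out shows an at least 2.4-fold higher number from compound 2 to compound 3 (0.39 log units; beyond the scatter), so this place responds to the group it carries, which the earlier step within the scatter did not show. Set against hydrogen on the aromatic carbon, the new group gives an at least 1.7-fold higher number from compound 1 to compound 3 (0.23 log units; that floor lies within the scatter), and the true size of both steps stays unknown, as the read-out ends at a ceiling: the limit of > 100000 nM in this assay, at which 1 of the 3 values shown sits.

Among the compounds shown here, the single step changes the ring atoms and adds the chlorine together, so the part each plays stays open. Also open, as far as these compounds go, is how an amine or a carboxylic acid at this place would read in this assay.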